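The source may report more compounds than this note shows. Statements on the series, on what has been measured and on what is new or still open speak of the compounds shown alone.

Compound 2 `NC(=O)c1c(NC(=O)c2ccccc2C(F)(F)F)sc2c1CCN(C(=S)Nc1ccccc1Cl)C2` gives the higher of the two numbers measured in a functional assay on HeLa cells (Homo sapiens) for antiproliferative activity, with a stated time of 24 h (a higher number here means a weaker inhibitor, a lower number a stronger inhibitor), namely 46900 nM; compound 1 `NC(=O)c1c(NC(=O)c2ccccc2F)sc2c1CCN(C(=S)Nc1ccccc1Cl)C2` gives 19400 nM in this assay. Within the data shown here, the one step measured so far at this carbon, a 2.4-fold higher number from compound 1 to compound 2 (0.38 log units; beyond the scatter), is the only step that bears on the change to compound 3 `Cc1ccccc1C(=O)Nc1sc2c(c1C(N)=O)CCN(C(=S)Nc1ccccc1Cl)C2`, which is methyl in place of trifluoromethyl on an aromatic carbon. Compound 3 is therefore expected to land between the two measured numbers, a step down of a 1.6-fold lower number from compound 2 to compound 3 (0.19 log units; within the scatter), though a result within the scatter of compound 2 would not surprise. The estimate for compound 3 in this assay is 30000 nM, with a range from 12000 nM to 75000 nM.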

Compound 3, half-maximal inhibitory concentration: 35300 nM
Beside the measured number, compound 3's estimate is 1.2-fold (0.07 log units) below it; measured number inside the range.
By their numbers in this assay, from the lowest: compounds 1, 3 and 2 (each within the scatter of the next, the first and the last beyond it).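

Methyl stays within the scatter of both other groups at this aromatic carbon, trifluoromethyl (a 1.3-fold lower number from compound 2 to compound 3 (0.12 log units; within the scatter)) and fluoro (a 1.8-fold higher number from compound 1 to compound 3 (0.26 log units; within the scatter)). Only compound 1 and compound 2 remain apart beyond the scatter, so the three groups give a narrow band in this assay and no clean ranking. No measurement at hand accounts for these numbers.

From the compounds shown here alone, whether an amine, a hydroxyl or a carboxylic acid on this carbon would leave that band remains open. So does the effect of changing the 2-chlorophenyl group on the thiourea side of the shared core.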